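Swapping an open-chain amine for a pyrrolidine on the oxime ether

The compounds below may be only part of what the source reports. "The series", "measured", "known", "first", "only" and "open" are said of these compounds alone.

Compound 1 `CCN(CC)C(=O)CO/N=C(\c1ccc(SC)cc1)c1cccc2ccccc12` carries a diethylcarbamoyl group on the chain attached to the oxime oxygen. In a functional assay on Ishikawa cells (Homo sapiens) for antiproliferative activity, read by MTT assay, with a stated time of 24 h (a lower number here means that less compound is needed, a higher number that more compound is needed for the effect), compound 1 gives only a limit, > 50000 nM. Compound 2 `CCCCN(C)CCCO/N=C(\c1ccc(SC)cc1)c1cccc2ccccc12` carries 2-(butyl(methyl)amino)ethyl in that position instead. In this assay compound 2 likewise gives only a limit, > 50000 nM. The step that the two limits leave unreadable from compound 1 to compound 2 thus cannot be read, as the limit of > 50000 nM in this assay, at which 2 of the 2 values shown sit, makes plain. Compound 3 `CSc1ccc(/C(=N\OCCCCN2CCCC2)c2cccc3ccccc23)cc1` differs from compound 2 by (pyrrolidin-1-yl)methyl in place of butyl(methyl)amino on a saturated chain carbon, three bonds along the chain from an oxygen on an unsaturated carbon. Within the data shown here, no measured step bears on this change, and the single measured step is unreadable, so there is no basis for expecting a shift in either direction beyond the scatter in this assay. Compound 3 is expected to show a step that the limit leaves unreadable from compound 2 to compound 3. Compound 3 is estimated at 60000 nM, within a range from 15000 nM to 250000 nM, and most likely again reported only as a limit.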

Compound 3, half-maximal effective concentration: > 50000 nM
Compound 3: no number, only a limit; the forecaster's own chance of this, stated with the estimate: 75%; the middle value lies beyond the limit too.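

No new step can be read for compound 3 against compound 2 or compound 1 in this assay, as all three give only a limit: the limit of > 50000 nM in this assay, at which 3 of the 3 values shown sit. The compounds shown leave open whether any of these chain changes alters the antiproliferative effect at all.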